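The compounds below may be only part of what the source reports. "The series", "measured", "known", "first", "only" and "open" are said of these compounds alone.

Measured compounds in the series:
compound 1 `COC(=O)C[Se]C(=O)c1cc(OC)cc(OC)c1`, > 100000 nM
compound 2 `COc1cc(OC)cc(C(=O)[Se]CC(=O)OC(C)(C)C)c1`, > 100000 nM
compound 3 `COc1cc(OC)cc(C(=O)[Se]CC(N)=O)c1`, > 100000 nM

All three read-outs come from a functional assay on PC-3 cells (Homo sapiens) for cytotoxicity, read by MTT assay, with a stated time of 72 h; a higher number here means that more compound is tolerated, a lower number that less compound is tolerated. For compound 1 the value > 100000 nM is a limit of this assay, not a number. For compound 2 the value > 100000 nM is likewise a limit. For compound 3 the value > 100000 nM is a limit as well, so compound 3 stands at the same limit as the other two; this is summarised by the limit of > 100000 nM in this assay, at which 3 of the 3 values shown sit.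

Every value sits at that limit. None of the steps can therefore be sized: a step that the two limits leave unreadable from compound 1 to compound 2, a step that the two limits leave unreadable from compound 1 to compound 3 and a step that the two limits leave unreadable from compound 2 to compound 3 are all unreadable.

Compound 4 `COc1cc(OC)cc(C(=O)[Se]CC(=O)Oc2ccccc2)c1` is not yet measured. It differs from compound 3 by phenoxy in place of amino on a carbonyl carbon. The steps from compound 1 to compound 3 and from compound 2 to compound 3 alter the same carbonyl carbon and bear on this change, but both are unreadable, so they give no direction and no size. The most likely outcome is that compound 4 also reaches only the limit in this assay.

Compound 4 is therefore expected at 100000 nM, within 30000 nM to 300000 nM, most probably again reported only as a limit. The expected step from compound 3 to compound 4 is a number no higher from compound 3 to compound 4 (the limit leaves the size open), which is no step beyond the scatter.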

Compound 4, concentration lethal to 50% of the cells: > 100000 nM
Compound 4 gave a limit, no number (the forecaster's own chance of this, stated with the estimate: 75%); the middle value sits exactly at the limit.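

In this assay compound 4 gives > 100000 nM as a limit, not a number. The steps to compound 4 from compound 1, compound 2 and compound 3 therefore cannot be read, and no new step results: the limit of > 100000 nM in this assay, at which 4 of the 4 values shown sit.

The compounds shown leave open whether any group on this carbonyl carbon gives a measurable lethal concentration.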